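Swapping a Sulfonyl for a Hydroxyl Group on the Chain

The source may report more compounds than this note shows. Statements on the series, on what has been measured and on what is new or still open speak of the compounds shown alone.

In an ADME assay on HEp-2 cells (Homo sapiens) for cytotoxicity, with a stated time of 4 days (a lower number here means that less compound is tolerated, a higher number that more compound is tolerated), three compounds have been measured so far.
Compound 1 `CS(=O)(=O)CCn1c(Cn2cc(S(C)(=O)=O)c3ccccc32)nc2ccccc21` gives > 100000 nM, a limit of the assay rather than a number.
Compound 2 `CN(C)S(=O)(=O)c1cn(Cc2nc3cc(Cl)ccc3n2CCCS(C)(=O)=O)c2ccccc12` gives > 100000 nM, again a limit.
Compound 3 `CS(=O)(=O)CCCn1c(Cn2nc(S(C)(=O)=O)c3ccncc32)nc2cc(Cl)ccc21` gives > 100000 nM, also a limit.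

Compound 3 therefore stands only at a limit in this assay, and the same holds across the set: the limit of > 100000 nM in this assay, at which 3 of the 3 values shown sit. Compound 4 `CC(C)(O)CCCn1c(Cn2nc(S(C)(=O)=O)c3ccncc32)nc2cc(Cl)ccc21` differs from compound 3 in one place, (1-hydroxy-1-methylethyl in place of methylsulfonyl on a saturated chain carbon, three bonds along the chain from an aromatic nitrogen), that is, 1-hydroxy-1-methylethyl in place of methylsulfonyl on a saturated chain carbon, three bonds along the chain from an aromatic nitrogen. Within the data shown here, no measured pair shows what such a swap does in this assay. Among the measured compounds shown here, with every value so far resting at the limit (the limit of > 100000 nM in this assay, at which 3 of the 3 values shown sit), no step beyond the scatter is expected a step that the limit leaves unreadable from compound 3 to compound 4. Compound 4 is estimated at 150000 nM, between 50000 nM and 500000 nM, most likely reported as a limit once more.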

Compound 4, half-maximal cytotoxic concentration: > 100000 nM
Compound 4 was reported as a limit; the forecaster's own chance of this, stated with the estimate: 80%; the middle value does not contradict the limit.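

No step can be read from compound 3 to compound 4, as both values are limits: the limit of > 100000 nM in this assay, at which 4 of the 4 values shown sit.

The compounds shown leave open how far 1-hydroxy-1-methylethyl in place of methylsulfonyl shifts the result in this assay at all.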